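This account rests on a few compounds, and the source may have more. Where it says the series, first, only, none or still open, it means among the compounds named here.

Compound 1 `CCCCCCCCc1ccc(OCC(=O)Cn2cnnn2)cc1` gives 22% in an ADME assay on S9 fraction from liver (Rattus norvegicus) for metabolic stability, read by LC-MS, using NADPH, with a stated time of 30 min (a lower number here means that less of the compound is left, a higher number that more of the compound is left), the second highest of three numbers. Compound 3 `CCCCCCCCc1ccc(OCC(=O)Cn2nnc(-c3cccnc3)n2)cc1` gives 12%, which lies within the scatter of compound 1, while compound 2 `CCCCCCCCc1ccc(OCC(=O)Cn2nnc(-c3ccc(C(=O)OC)cc3)n2)cc1` gives 64%, well beyond it. Among the compounds with values here, the one step between measured neighbours, a number 52 percentage points lower from compound 2 to compound 3 (beyond the scatter), shows how strongly the group on that aromatic carbon of the core can move this assay. Compound 4 `CCCCCCCCc1ccc(OCC(=O)Cn2nnnc2-c2cccc(C(=O)O)c2)cc1` differs from compound 1 by 3-carboxyphenyl in place of hydrogen on an aromatic carbon. Within the data shown here, no measured step puts an aryl group in place of hydrogen at that position, and compounds 2 and 3 show either outcome is possible. Compound 4 is therefore expected near the middle of the observed spread, at 35% with a range of 12% to 65%, meaning an expected step of a number 13 percentage points higher from compound 1 to compound 4 (beyond the scatter).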

Compound 4, percent of the compound remaining: < 5%
Compound 4: no number, only a limit (the forecaster's own chance of this, stated with the estimate: 5%); at least 30 percentage points between middle value and limit.
By their numbers in this assay, from the lowest: compounds 3 and 1 (each within the scatter of the next); then compound 2. At a limit, below all of these: compound 4.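

In this assay, the reading for compound 4 is a limit of the assay and not a number: the limit of < 5% in this assay, at which 1 of the 4 values shown sits. Within the data shown here, the step can therefore be given only as a bound, a number at least 17 percentage points lower from compound 1 to compound 4 (beyond the scatter), but it is the first measured change on this aromatic carbon between two ring nitrogen atoms. It shows that 3-carboxyphenyl in place of hydrogen at this position leaves less of the compound after the incubation, not more.

The compounds shown leave open whether this step belongs to the phenyl ring or to its carboxylic acid, which a plain phenyl or a methyl ester on the same carbon would separate.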